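The source may report more compounds than this note shows. Statements on the series, on what has been measured and on what is new or still open speak of the compounds shown alone.

In a toxicity assay on J774.A1 cells (Mus musculus) for cytotoxicity, read by SYBR Green assay, with a stated time of 1 h (on this read-out lower numbers stand for an effect already at smaller amounts and higher numbers for an effect only at larger amounts of compound), compound 1 `CN(C)c1ccc2cc(-c3cccc(Cl)c3)c(N)nc2c1` gives 13000 nM and compound 2 `CN(C)c1ccc2cc(-c3cc(Cl)ccc3Cl)c(N)nc2c1` gives 9800 nM while compound 3 `CN(C)c1ccc2cc(-c3cc(Cl)cc(Cl)c3)c(N)nc2c1` gives 3700 nM as the lowest of the three numbers. Compound 4 `Nc1nc2cc(N3CCCC3)ccc2cc1-c1cc(Cl)cc(Cl)c1` differs from compound 3 in one place, with pyrrolidin-1-yl in place of dimethylamino on an aromatic carbon and the rest unchanged. Both measured steps instead put chloro in place of hydrogen on an aromatic carbon (a 1.3-fold lower number from compound 1 to compound 2 (0.12 log units; within the scatter)) and (a 3.5-fold lower number from compound 1 to compound 3 (0.55 log units; beyond the scatter)) and the larger of them is only modest. Neither alters the dimethylamino group, so they offer only indirect guidance, and no step beyond the scatter is expected in this assay in either direction. The estimated step (a 1.2-fold lower number from compound 3 to compound 4 (0.09 log units; within the scatter)) is correspondingly small. For compound 4 the expected value is 3000 nM (estimated range 1200 nM to 7500 nM).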

Compound 4, half-maximal effective concentration: 1400 nM
Beside the measured number, compound 4's estimate is 2.1-fold (0.33 log units) above it, within the range that was stated.
By their numbers in this assay, from the lowest: compound 4; then compound 3; then compounds 2 and 1 (each within the scatter of the next).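

Among these compounds, the step from dimethylamino to pyrrolidin-1-yl gives a 2.6-fold lower number from compound 3 to compound 4 (0.42 log units; beyond the scatter) in this assay and shows that the number responds to this position, not only to the chloro groups changed in the earlier steps. Toxicity to these cells thus appears at smaller amounts with the ring-bearing group, though only modestly so. No supporting information explains this shift.

Going by these compounds, whether piperidin-1-yl or morpholin-4-yl at this position would shift the number further remains open. So does whether pyrrolidin-1-yl would act alike with the chloro patterns of compound 1 and compound 2.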